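The source may hold more compounds than are shown below. What is called first, only, known or untested is meant among the compounds shown, and "the series" means these compounds.

Measured so far:
compound 1 `CCOC(=O)c1ccc(-c2nn(Cc3ccc(OC)cc3)c3ccccc23)cc1` — > 10000 nM
compound 2 `CC(C)OC(=O)c1ccc(-c2nn(Cc3ccccc3)c3ccccc23)cc1` — > 10000 nM

In a functional assay on cells (Platelet, Homo sapiens) for inhibition (on this read-out higher numbers stand for weaker inhibition and lower numbers for stronger inhibition), compound 1 gives only a limit, > 10000 nM, and no number. Compound 2 likewise gives a limit in this assay, > 10000 nM. Both values sit at the limit of > 10000 nM in this assay, at which 2 of the 2 values shown sit, so compound 1 cannot be placed relative to compound 2 on the numbers shown, and no step between measured compounds can be drawn from them.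

Compound 3 `CCOC(=O)c1ccc(-c2nn(-c3ccccc3)c3ccccc23)cc1` differs from compound 1 by phenyl in place of 4-methoxybenzyl on an aromatic nitrogen. Because both measured values rest at the limit of > 10000 nM in this assay, at which 2 of the 2 values shown sit, the step from compound 1 to compound 3 in this assay is expected to be none beyond the scatter, with compound 3 most likely again returning a limit rather than a number. The step from compound 1 to compound 3 is estimated as a step that the limit leaves unreadable from compound 1 to compound 3. Compound 3 is estimated at 15000 nM in this assay, with an expected range from 4000 nM to 60000 nM.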

Compound 3, half-maximal inhibitory concentration: > 10000 nM
Compound 3: no number, only a limit; the forecaster's own chance of this, stated with the estimate: 80%; the middle value lies beyond the limit too.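

In this assay compound 3 gives > 10000 nM, a limit and not a number. No step from compound 1 to compound 3 can be read, because both compounds rest at the same limit: the limit of > 10000 nM in this assay, at which 3 of the 3 values shown sit.

The compounds shown leave open whether any group on the aromatic nitrogen gives a number rather than a limit in this assay.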